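This account rests on a few compounds, and the source may have more. Where it says the series, first, only, none or still open, it means among the compounds named here.

Compound 1 `O=Cc1cccc(OCc2cn(Cc3ccccc3)nn2)c1` gives > 50000 nM in a functional assay on DU-145 cells (Homo sapiens) for inhibition, read by MTT assay, with a stated time of 48 h; a lower number here means a stronger inhibitor, a higher number a weaker inhibitor; this is a limit of the assay and not a number.
Compound 2 `COc1cc(Cn2cc(COc3cccc(/C=C4\C(=O)Nc5ccccc54)c3)nn2)cc(OC)c1` gives "not determined" (no result reported) in this assay.

The piece follows a single step that starts from compound 2. On the numbers shown, compound 2 stands nowhere in particular: it has no single number in this assay, and of the two results given for the study, one sits at the limit of > 50000 nM in this assay, at which 1 of the 2 values shown sits, while the other is simply absent. Among the measured compounds shown here, there is therefore no measured pair of compounds from which the size of any step could be read.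

Compound 3 `COc1cc(Cn2cc(COc3cccc(/C=C4/C(=O)Nc5ccccc54)c3)nn2)cc(OC)c1` is built from exactly the same atoms and bonds as compound 2; the difference is the two compounds have the same atoms and bonds and differ only in configuration as drawn: 1 of 1 stereo elements differ; a double bond is drawn Z in compound 2 and E in compound 3. For a change of this kind nothing in the results allows a size or a direction to be fixed, so in this assay the expectation is a step that may go either way and need not rise beyond the usual scatter. Compound 3 is estimated at 8000 nM, with a range from 800 nM to 50000 nM, and a real chance that only a limit is reported.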

Compound 3, half-maximal inhibitory concentration: 25600 nM
Beside the measured number, compound 3's estimate is 3.2-fold (0.51 log units) below it; measured number inside the range.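

Compound 2 has no number in this assay to set against compound 3, which gives 25600 nM there, so no step can be read between the two. Going by these compounds, what stays open is whether the double bond being drawn Z in compound 2 or E in compound 3 changes the result in this assay at all, and in which direction.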